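This account rests on a few compounds, and the source may have more. Where it says the series, first, only, none or still open, it means among the compounds named here.

Series notes. Compound 3 `CC(C)(CO)Cn1c(Cn2nc(S(C)(=O)=O)c3ccncc32)nc2cc(Cl)ccc21` carries the shared core with a 1-(hydroxymethyl)-1-methylethyl group on a saturated chain carbon bound to an aromatic nitrogen. In an ADME assay on HEp-2 cells (Homo sapiens) for cytotoxicity, with a stated time of 4 days (on this read-out lower numbers stand for higher toxicity in this test and higher numbers for lower toxicity in this test), compound 3 gives only a limit, > 100000 nM. Compound 1 `CS(=O)(=O)c1nn(Cc2nc3cc(Cl)ccc3n2CCCCO)c2cnccc12` likewise gives only a limit in this assay, > 100000 nM. Compound 2 `CC(C)(O)CCn1c(Cn2nc(S(C)(=O)=O)c3ccncc32)nc2cc(Cl)ccc21` also reaches only a limit in this assay, > 100000 nM. The steps among these three are a step that the two limits leave unreadable from compound 1 to compound 2, a step that the two limits leave unreadable from compound 1 to compound 3 and a step that the two limits leave unreadable from compound 2 to compound 3; the limit of > 100000 nM in this assay, at which 3 of the 3 values shown sit, is all the series shows, so compound 3 stands where every measured member stands, at the limit. Compound 4 `CC(C)(O)CCCn1c(Cn2nc(S(C)(=O)=O)c3ccncc32)nc2cc(Cl)ccc21` differs from compound 3 by 3-hydroxy-3-methylbutyl in place of 1-(hydroxymethyl)-1-methylethyl on a saturated chain carbon bound to an aromatic nitrogen. Going by the values given here, no measured step bears on this change with a readable size, since all three steps stay unreadable between limits. No step beyond the scatter is therefore expected in this assay. Compound 4 is expected to sit again at the limit, 100000 nM, within 50000 nM to 200000 nM. This corresponds to an expected step of a number no higher from compound 3 to compound 4 (the limit leaves the size open).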

Compound 4, half-maximal cytotoxic concentration: > 100000 nM
Compound 4 was reported as a limit (the forecaster's own chance of this, stated with the estimate: 85%); the middle value sits exactly at the limit.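

In this assay compound 4 gives only a limit, > 100000 nM. Going by these compounds alone, no step from compound 1, compound 2 or compound 3 to compound 4 can be read. The compounds shown leave open what half-maximal cytotoxic concentration any of them has and whether these chain changes alter it, as the series shows only this: the limit of > 100000 nM in this assay, at which 4 of the 4 values shown sit.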